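Cytotoxicity limits across the hexyl and alkynyl series

The source may report more compounds than this note shows. Statements on the series, on what has been measured and on what is new or still open speak of the compounds shown alone.

Compound 3 `CCCCCCc1cc2cn(COCCO)c(=O)nc2o1` carries a hexyl chain on the shared core. In a functional assay on HEL cells (Homo sapiens), read by microscopy (a higher number here means that more compound is tolerated, a lower number that less compound is tolerated), compound 3 gives >= 400000 nM, which is a limit of the assay and not a number. Compound 1 `CCCCCCC#Cc1cc2cn(COCCO)c(=O)nc2o1` is likewise known only by a limit; in this assay compound 1 gives > 200000 nM. Compound 2 `CCCCC#Cc1cc2cn(COCCO)c(=O)nc2o1` is also known only by a limit, and in this assay compound 2 gives > 100000 nM. Every value in the set is a limit, so the step that the two limits leave unreadable from compound 1 to compound 2 and the step that the two limits leave unreadable from compound 2 to compound 3 have no readable size, and compound 3 cannot be ranked against the other two on these numbers; it stands at one of three limits, as do the limit of > 100000 nM in this assay, at which 1 of the 3 values shown sits, and the limit of > 200000 nM in this assay, at which 1 of the 3 values shown sits, for the other members, with the limit of >= 400000 nM in this assay, at which 1 of the 3 values shown sits, belonging to compound 3 itself.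

Compound 4 `CCCCCC#Cc1cc2cn(COCCO)c(=O)nc2o1` differs from compound 3 by hept-1-yn-1-yl in place of hexyl on an aromatic carbon. The two measured steps bear on this change, since each exchanges chain length or saturation on the same position of the core, yet neither was sized. The step of an at least 2.0-fold lower number from compound 3 to compound 4 (0.30 log units; that floor lies within the scatter) is therefore expected to stay within the scatter, with a limit rather than a number as the likely outcome. Compound 4 is estimated at 200000 nM, between 100000 nM and 400000 nM.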

Compound 4, minimum cytotoxic concentration: >= 100000 nM
Compound 4: only a limit was reported; the forecaster's own chance of this, stated with the estimate: 90%; the middle value is on the limit's open side.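

In this assay compound 4 gives >= 100000 nM, which is a limit of the assay and not a number. Among the compounds shown here, compound 1, compound 2 and compound 3 are also known only by limits, so no step from any of them to compound 4 can be read. As far as these compounds go, whether any of these four compounds is tolerated differently from the others in this assay stays open.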